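Ester Variation on a Cyclohexyl Anilide Core

This account rests on a few compounds, and the source may have more. Where it says the series, first, only, none or still open, it means among the compounds named here.

Measured compounds:
compound 1, `O=C(OC1(C(=O)Nc2ccc([N+](=O)[O-])cc2)CCCCC1)c1ccc([N+](=O)[O-])cc1`, 761 nM
compound 2, `CCOC(=O)c1ccccc1C(=O)OC1(C(=O)Nc2ccc([N+](=O)[O-])cc2)CCCCC1`, 386 nM

Compound 1 `O=C(OC1(C(=O)Nc2ccc([N+](=O)[O-])cc2)CCCCC1)c1ccc([N+](=O)[O-])cc1` was tested in an ADME assay on WI-38 cells (Homo sapiens) for inhibition, read by MTT assay, with a stated time of 72 h (a lower number here means a stronger inhibitor, a higher number a weaker inhibitor), and gives 761 nM. Compound 2 `CCOC(=O)c1ccccc1C(=O)OC1(C(=O)Nc2ccc([N+](=O)[O-])cc2)CCCCC1` in this assay gives 386 nM, and the two numbers lie within the usual scatter of each other, so no order between them can be read from the data. Compound 3 `CCC(=O)OC1(C(=O)Nc2ccc([N+](=O)[O-])cc2)CCCCC1` has not yet been measured. It differs from compound 1 in one place: ethyl in place of 4-nitrophenyl on a carbonyl carbon. Going by the values given here, no step between measured compounds bears on this change, since both measured compounds carry an aromatic ester. With only an aromatic-to-alkyl swap to go on, the expectation for the step in this assay from compound 1 to compound 3 is a moderate move toward a higher number, estimated as a 2.1-fold higher number from compound 1 to compound 3 (0.32 log units; beyond the scatter). Compound 3 is therefore expected to give about 1600 nM, estimated to fall between 500 nM and 5000 nM.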

Compound 3, half-maximal inhibitory concentration: 44.6 nM
Compound 3: middle estimate off by 36-fold (1.55 log units), on the high side, outside the stated range (below it).
By their numbers in this assay, from the lowest: compound 3; then compounds 2 and 1 (each within the scatter of the next).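

In this assay, the group on the carbonyl carbon of the ester proves to matter a great deal: ethyl in place of 4-nitrophenyl gives a 17-fold lower number from compound 1 to compound 3 (1.23 log units; beyond the scatter). This step shows that an aromatic group is not required at this position for a low number, and that a group of two carbons can serve far better here than the larger 4-nitrophenyl. Nothing available explains why the number falls with this change.

As far as these compounds go, it remains open whether a methyl, a propyl or a longer chain on this carbonyl carbon would give a lower or higher number than ethyl. From the compounds shown here alone, it is also open whether a cyclohexyl group or an unsubstituted phenyl would stay close to ethyl or to 4-nitrophenyl.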